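Tail exchange on the aromatic nitrogen: compound 2 to compound 4

A few compounds are considered here, and "the series" means these few. Any claim that something is new, unique, unknown or untested is made for them only; others in the source may bear on it.

Three measured compounds share one core and differ only in the tail carried beyond the alkyne. Compound 1 `CNC(=O)[C@@]12C[C@@H]1[C@@H](n1cnc3c(NCc4cccc(Cl)c4)nc(C#CCCC(=O)NCCNC(=O)CCCCC4SCC5NC(=O)NC54)nc31)[C@H](O)[C@@H]2O` in an assay on CHO cells for displacement of a labelled ligand from adenosine receptor A3 (Homo sapiens), read by scintillation counting (a lower number here means a stronger inhibitor, a higher number a weaker inhibitor), gives 36.4 nM. Compound 3 `CNC(=O)[C@@]12C[C@@H]1[C@@H](n1cnc3c(NCc4cccc(Cl)c4)nc(C#CCCCc4cn(-c5cccc([N+](=O)[O-])c5)nn4)nc31)[C@H](O)[C@@H]2O` in this assay gives 26 nM. Compound 2 `CNC(=O)[C@@]12C[C@@H]1[C@@H](n1cnc3c(NCc4cccc(Cl)c4)nc(C#CCCCCc4cn(-c5ccc(C(=O)O)cc5)nn4)nc31)[C@H](O)[C@@H]2O`, which carries the 4-carboxyphenyl on the aromatic nitrogen, in this assay gives 180 nM, the highest of the three numbers; its gap to compound 1 and its gap to compound 3 both lie beyond the scatter. Compound 4 `CNC(=O)[C@@]12C[C@@H]1[C@@H](n1cnc3c(NCc4cccc(Cl)c4)nc(C#CCCCCc4cn(CCNC(C)=O)nn4)nc31)[C@H](O)[C@@H]2O` is the unmeasured member. Its change from compound 2 is 2-acetamidoethyl in place of 4-carboxyphenyl on an aromatic nitrogen. For the measured compounds named here, no pair of measured compounds isolates this exchange, so the step can only be judged from the tails already seen. Because compound 1 reaches 36.4 nM with an amide-containing chain in its tail, compound 4 is expected to move toward the lower numbers, a downward step a 3.6-fold lower number from compound 2 to compound 4 (0.56 log units; beyond the scatter) beyond the scatter. Compound 4 is estimated at 50 nM, with a range of 15 nM to 160 nM.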

Compound 4, inhibition constant: 22.3 nM
Compound 4: the middle estimate sits 2.2-fold (0.35 log units) above what was measured; the range from low to high includes it.
By their numbers in this assay, from the lowest: compounds 4, 3 and 1 (each within the scatter of the next); then compound 2.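

In this assay, for the compounds shown here, the exchange on the aromatic nitrogen of the five-membered aromatic ring gives an 8.1-fold lower number from compound 2 to compound 4 (0.91 log units; beyond the scatter), the first single-place step that can be read at this position. The number therefore depends on the group carried here: 2-acetamidoethyl, with no ring and fewer heavy atoms, gives the lower number, so a six-membered aromatic ring on this nitrogen is not required. Nothing in the data shown gives a reason for this step.

On these data alone, the exchange alters the ring and the end group together, so it remains open whether the step follows the loss of the six-membered aromatic ring or of the carboxylic acid. A plain phenyl, a 2-aminoethyl or a carboxylic acid on an ethyl chain at the same nitrogen would separate these two changes.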